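Methoxy for hydrogen on the anilide ring: second occurrence

The source may hold more compounds than are shown below. What is called first, only, known or untested is meant among the compounds shown, and "the series" means these compounds.

Compound 2 `COc1cc(NC(=O)c2cccc(NC(=O)C(C)Br)c2)cc(OC)c1` and compound 1 `COc1cc(NC(=O)c2cccc(NC(=O)C(C)Br)c2)cc(OC)c1OC` share a core; in a functional assay on MOLT-3 cells (Homo sapiens) for antiproliferative activity (on this read-out lower numbers stand for stronger inhibition and higher numbers for weaker inhibition), compound 2 gives 610 nM and compound 1 gives 670 nM, so the step of a 1.1-fold higher number from compound 2 to compound 1 (0.04 log units; within the scatter) is methoxy in place of hydrogen on an aromatic carbon. Compound 3 `COc1ccc(NC(=O)c2cc(NC(=O)C(C)Br)ccc2F)cc1` rests on a different core; how the two cores differ is not broken down here. In this assay compound 3 gives 250 nM. Compound 4 `COc1ccc(NC(=O)c2cc(NC(=O)C(C)Br)ccc2F)cc1OC` is unmeasured; it differs from compound 3 by methoxy in place of hydrogen on an aromatic carbon. This is the same kind of change as that from compound 2 to compound 1, not the same: there the entering methoxy stood ortho to two methoxy groups and para to a large group, here ortho to a methoxy group and meta to a large group. Since the earlier step lay within the scatter, the step is expected to be a 1.1-fold higher number from compound 3 to compound 4 (0.05 log units; within the scatter). For compound 4 the estimate in this assay is 280 nM, between 120 nM and 650 nM.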

Compound 4, half-maximal inhibitory concentration: 470 nM
Compound 4: the middle estimate sits 1.7-fold (0.22 log units) below what was measured; the measured number falls inside the stated range.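

In this assay, methoxy in place of hydrogen on an aromatic carbon gives a 1.9-fold higher number from compound 3 to compound 4 (0.27 log units; within the scatter), so this pair is not separated by the change. The two steps do not differ across the two cores: the same change on two cores in this assay, a 1.1-fold higher number (0.04 log units; within the scatter) from compound 2 to compound 1 and a 1.9-fold higher number (0.27 log units; within the scatter) from compound 3 to compound 4, 1.7-fold (0.23 log units) apart, within the scatter of two such steps. This shows that, on these two cores, the change carries over with no step beyond the scatter, but two pairs with the entering methoxy in different surroundings do not show that it would carry to a further core.

On these data alone, whether a hydroxyl, an amine or a longer chain such as ethoxy on the same aromatic carbon would behave likewise remains open. Also open, as far as these compounds go, is how methoxy behaves where no methoxy group stands ortho to it.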